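This account rests on a few compounds, and the source may have more. Where it says the series, first, only, none or still open, it means among the compounds named here.

Three compounds have been measured in a functional assay on the whole organism for inhibition, with Rattus norvegicus as the target, read by paw edema, with stated times of 30 min and 3 h, at a dose of 0.28 mmol/kg by the oral route; a lower number here means less inhibition, a higher number more inhibition at the dose given (going by the name of the read-out):

compound 1 `COc1ccc(-n2nc(C(=O)Nc3ccccc3OC)nc2-c2cc(OC)c(OC)c(OC)c2)cc1` gives 30%;
compound 2 `COc1ccc(-n2nc(C(=O)Nc3ccc(C)cc3)nc2-c2cc(OC)c(OC)c(OC)c2)cc1` gives 60%;
compound 3 `COc1ccc(-n2nc(C(=O)Nc3cccc(F)c3)nc2-c2cc(OC)c(OC)c(OC)c2)cc1` gives 72%.

Compound 3 stands highest of the three numbers: its step from compound 2 is a number 12 percentage points higher from compound 2 to compound 3 (beyond the scatter), and its step from compound 1 is a number 42 percentage points higher from compound 1 to compound 3 (beyond the scatter), both beyond the scatter. Compound 4 `COc1ccc(-n2nc(C(=O)Nc3ccc(C(F)(F)F)cc3)nc2-c2cc(OC)c(OC)c(OC)c2)cc1` has not yet been measured. It differs from compound 3 in one place: 4-(trifluoromethyl)phenyl in place of 3-fluorophenyl on an amide-type nitrogen. Going by the values given here, no measured step turns 3-fluorophenyl into 4-(trifluoromethyl)phenyl, so the comparison is indirect. Among the compounds with values here, the steps that bear on it are the two that lead into compound 3, a number 42 percentage points higher from compound 1 to compound 3 (beyond the scatter) and a number 12 percentage points higher from compound 2 to compound 3 (beyond the scatter), and the step that introduces 4-methylphenyl, a number 30 percentage points higher from compound 1 to compound 2 (beyond the scatter). Compound 2, which carries 4-methylphenyl, sits a modest amount below compound 3. The account therefore expects compound 4 to land slightly below compound 3 or close to it, a step of a number 10 percentage points lower from compound 3 to compound 4 (within the scatter). Compound 4 is estimated at 62% in this assay, within a range from 45% to 78%.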

Compound 4, a percentage reported as inhibition, in the whole organism at one dose (the size of the read-out at that dose, not a potency): 65%
Estimate against measurement, compound 4: 3 percentage points below; the range from low to high includes it.
By their numbers in this assay, from the lowest: compound 1; then compounds 2, 4 and 3 (each within the scatter of the next, the first and the last beyond it).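

In this assay, trifluoromethyl in place of methyl on an aromatic carbon gives a number 5 percentage points higher from compound 2 to compound 4 (within the scatter), so this change at the phenyl ring on the amide-type nitrogen does not separate the two groups. The 4-(trifluoromethyl)phenyl group also cannot be told apart from 3-fluorophenyl, with a number 7 percentage points lower from compound 3 to compound 4 (within the scatter), yet it stands clear of 2-methoxyphenyl, with a number 35 percentage points higher from compound 1 to compound 4 (beyond the scatter); among these four compounds, only compound 1 stands apart from all of the others, while compound 2 and compound 3 differ beyond the scatter and compound 4 does not separate from either. Nothing available explains these numbers.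

The compounds shown leave open how an amine or a carboxylic acid on that phenyl ring would read in this assay. They also leave open whether the low number of compound 1, 30%, belongs to the methoxy group itself or to where it sits on the ring.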